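Inverted ring configuration in a silyl-protected bicyclic acetate

This account rests on a few compounds, and the source may have more. Where it says the series, first, only, none or still open, it means among the compounds named here.

Compound 2 `CC(=O)O[C@@H]1OC=C[C@@H]2[C@H]1[C@@H](C)C[C@H]2O[Si](c1ccccc1)(c1ccccc1)C(C)(C)C` holds the lowest number of the two values measured in a functional assay on HBL-100 cells (Homo sapiens) for antiproliferative activity, read by sulforhodamine B assay, with a stated time of 48 h (a higher number here means a weaker inhibitor of growth, a lower number a stronger inhibitor of growth), where compound 2 gives 500 nM; compound 1 `CC(=O)OC1OC=CC2C1CC[C@H]2O` gives 16000 nM in this assay. Compound 3 `CC(=O)O[C@H]1OC=C[C@H]2[C@@H]1[C@H](C)C[C@H]2O[Si](c1ccccc1)(c1ccccc1)C(C)(C)C` differs from compound 2 only in configuration as drawn: the two compounds have the same atoms and bonds and differ only in configuration as drawn: 4 of 5 stereo elements differ; a stereocentre at a saturated ring carbon is drawn S in compound 2 and R in compound 3; a stereocentre at a saturated ring carbon is drawn R in compound 2 and S in compound 3; a stereocentre at a saturated ring carbon is drawn R in compound 2 and S in compound 3; a stereocentre at a saturated ring carbon is drawn S in compound 2 and R in compound 3. Going by the values given here, no measured pair shows what such an inversion does here, and nothing else is known about it. A step of moderate size toward a higher number, beyond the scatter, is expected from compound 2 to compound 3 a 5.0-fold higher number from compound 2 to compound 3 (0.70 log units; beyond the scatter). Compound 3 is estimated at 2500 nM, within 400 nM to 20000 nM.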

Compound 3, concentration for 50% growth inhibition: 380 nM
The estimate for compound 3 lay 6.6-fold (0.82 log units) above the measured number, outside the stated range (below it).
By their numbers in this assay, from the lowest: compounds 3 and 2 (each within the scatter of the next); then compound 1.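

Inverting four of the five stereo elements gives no difference that can be read in this assay, with a 1.3-fold lower number from compound 2 to compound 3 (0.12 log units; within the scatter). The pair therefore shows what compound 1 could not: for these two silyl-protected acetates, growth inhibition does not separate the two drawn configurations, and the comparison tests configuration alone: the fact that compounds 2 and 3 differ only in the configuration as drawn.

The compounds shown leave open whether an amine or a carboxylic acid in place of the acetate would keep the number, and whether the inversions would count for as little without the silyl group.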